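Dimethoxyphenyl replacing dichlorophenyl on the enone carbonyl

The source may hold more compounds than are shown below. What is called first, only, known or untested is meant among the compounds shown, and "the series" means these compounds.

Of the compounds shown here, three have been measured in a functional assay on Malme-3M cells (Homo sapiens) for inhibition, read by sulforhodamine B assay, with a stated time of 48 h; a lower number here means a stronger inhibitor of growth, a higher number a weaker inhibitor of growth. Compound 1 `COc1ccc(-c2cc(/C=C/C(=O)c3ccc(OC)c(OC)c3)[nH]n2)cc1` gives 1620 nM. Compound 3 `COc1ccc(-c2cc(/C=C/C(=O)c3ccc(N)cc3)[nH]n2)cc1` gives 2180 nM. Compound 2 `COc1cc(-c2cc(/C=C/C(=O)c3ccc(Cl)c(Cl)c3)[nH]n2)cc(OC)c1OC` gives 29200 nM, the highest of the three numbers, beyond the scatter above both compound 3 and compound 1. Among the measured compounds shown here, no pair among the measured compounds differs in a single place, so no step can be read directly.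

Compound 4 `COc1ccc(C(=O)/C=C/c2cc(-c3cc(OC)c(OC)c(OC)c3)n[nH]2)cc1OC` is not yet measured. Relative to compound 2 the change is 3,4-dimethoxyphenyl in place of 3,4-dichlorophenyl on a carbonyl carbon. Compound 1, which also carries 3,4-dimethoxyphenyl on the carbonyl carbon, gives 1620 nM, so a downward step from compound 2 to compound 4, beyond the scatter, is expected: an 8.3-fold lower number from compound 2 to compound 4 (0.92 log units; beyond the scatter). The estimate for compound 4 is 3500 nM, with a range from 1200 nM to 12000 nM.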

Compound 4, concentration for 50% growth inhibition: 1990 nM
The estimate for compound 4 lay 1.8-fold (0.25 log units) above the measured number, within the range that was stated.
By their numbers in this assay, from the lowest: compounds 1, 4 and 3 (each within the scatter of the next); then compound 2.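

In this assay, among the compounds shown here, the change at this carbonyl carbon gives the first step that can be read: 3,4-dimethoxyphenyl in place of 3,4-dichlorophenyl brings a 15-fold lower number from compound 2 to compound 4 (1.17 log units; beyond the scatter), so the high number of compound 2 goes with its 3,4-dichlorophenyl at this position. Compound 4 and compound 1, which share 3,4-dimethoxyphenyl there, stand within the scatter of each other. Nothing available explains the size of this step.

Still open, going by these compounds, is whether a hydroxyl group or a fluorine on this phenyl ring would give a number near that of compound 4 or of compound 2.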